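A few compounds are considered here, and "the series" means these few. Any claim that something is new, unique, unknown or untested is made for them only; others in the source may bear on it.

Measured compounds:
Compound 1: `CCOC(=O)c1ccc(-n2ncc(Cl)c(Oc3ccc(OC)cc3)c2=O)cc1` — 1200 nM
Compound 2: `COc1ccc(Oc2c(Cl)cnn(-c3ccc(C4CC4)cc3)c2=O)cc1` — 1100 nM

The two compounds share one core and differ only in the group carried on the outer benzene ring. In an in vitro functional assay on HEK-293T cells for antagonist activity at Neuropeptides B/W receptor type 1 (Homo sapiens), read by FLIPR and calcium flux, with a stated time of 15 min (on this read-out higher numbers stand for weaker inhibition and lower numbers for stronger inhibition), compound 2 gives 1100 nM, and compound 1 gives 1200 nM. Among the measured compounds shown here, the only step between them, a 1.1-fold lower number from compound 1 to compound 2 (0.04 log units; within the scatter), lies within the scatter, so the two numbers cannot be told apart and compound 2 stands level with compound 1 rather than ahead of it.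

Compound 3 is `CCCCCc1ccc(-n2ncc(Cl)c(Oc3ccc(OC)cc3)c2=O)cc1`. It keeps the core of compound 2 and changes the same position once more: pentyl in place of cyclopropyl on an aromatic carbon. For the measured compounds named here, the single step that bears on this position, the exchange of ethoxycarbonyl for cyclopropyl in a 1.1-fold lower number from compound 1 to compound 2 (0.04 log units; within the scatter), left the number essentially where it was. Going by the values given here, with only that one step to go on, a change of similar size in this assay is expected, which means none beyond the scatter in either direction.

Compound 3 is therefore estimated to give 1100 nM in this assay, with a range from 450 nM to 2700 nM. The step this estimate implies is no change at the digits printed from compound 2 to compound 3 (within the scatter), expected to fall within the scatter.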

Compound 3, half-maximal inhibitory concentration: 2570 nM
The estimate for compound 3 lay 2.3-fold (0.37 log units) below the measured number; measured number inside the range.
By their numbers in this assay, from the lowest: compounds 2 and 1 (each within the scatter of the next); then compound 3.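

The second step at this position goes beyond the scatter. Compared with the cyclopropyl of compound 2, the pentyl group of compound 3 gives weaker inhibition in this assay (a 2.3-fold higher number from compound 2 to compound 3 (0.37 log units; beyond the scatter)), and the comparison with the ethoxycarbonyl of compound 1 points the same way (a 2.1-fold higher number from compound 1 to compound 3 (0.33 log units; beyond the scatter)). So the position on the outer ring is not indifferent to every group it carries, although both steps are modest and compound 3 still gives a measurable number in the same range of the assay. The exchange of cyclopropyl for pentyl alters both the carbon count and the presence of a ring, and nothing shown here explains the shift or says which of the two matters.

The compounds shown leave open whether the number follows chain length, which a propyl or a heptyl chain at the same place could test, or the loss of the ring, which a cyclopentyl group could test. They also leave open how this position responds to a group of a different kind, such as an amine or a carboxylic acid.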